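This account rests on a few compounds, and the source may have more. Where it says the series, first, only, none or still open, it means among the compounds named here.

Working notes on the series. The three measured compounds share one core, carrying a sulfonamide whose nitrogen is varied. Compound 1 `NS(=O)(=O)c1ccc(N/C(S)=N\c2ccnc3cc(C(F)(F)F)ccc23)cc1` has hydrogen on that nitrogen; in a functional assay on HT-1080 cells (Homo sapiens) for antiproliferative activity, read by sulforhodamine B assay, with a stated time of 48 h (a lower number here means a stronger inhibitor, a higher number a weaker inhibitor), compound 1 gives 31000 nM. Compound 2 `Cc1ccnc(NS(=O)(=O)c2ccc(N/C(S)=N\c3ccnc4cc(C(F)(F)F)ccc34)cc2)n1` carries a 4-methylpyrimidin-2-yl there and in this assay compound 2 gives 28700 nM. Compound 3 `COc1cc(NS(=O)(=O)c2ccc(N/C(S)=N\c3ccnc4cc(C(F)(F)F)ccc34)cc2)nc(OC)n1` carries a 2,6-dimethoxypyrimidin-4-yl, and in this assay compound 3 gives 29500 nM. The steps are small: a 1.1-fold lower number from compound 1 to compound 2 (0.03 log units; within the scatter), a 1.1-fold lower number from compound 1 to compound 3 (0.02 log units; within the scatter) and a 1.0-fold higher number from compound 2 to compound 3 (0.01 log units; within the scatter). Compound 3 thus sits within the scatter of both neighbours, and the three numbers show no separation.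

Compound 4 `COc1ncnc(NS(=O)(=O)c2ccc(N/C(S)=N\c3ccnc4cc(C(F)(F)F)ccc34)cc2)c1OC` is the next member: 5,6-dimethoxypyrimidin-4-yl in place of 2,6-dimethoxypyrimidin-4-yl on a sulfonamide nitrogen. The two structures hold the same atoms, joined differently. Among the measured compounds shown here, the steps that bear on this change are those at the same nitrogen, a 1.1-fold lower number from compound 1 to compound 3 (0.02 log units; within the scatter) and a 1.0-fold higher number from compound 2 to compound 3 (0.01 log units; within the scatter), the second being the closest analogue, one pyrimidinyl swapped for another, and both within the scatter. For the measured compounds named here, no measured step at this nitrogen has moved the number beyond the scatter, so no step beyond the scatter is expected in this assay in either direction. The expected step is no change at the digits printed from compound 3 to compound 4 (within the scatter). Compound 4 is therefore estimated at 29500 nM, with a range from 15000 nM to 60000 nM.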

Compound 4, half-maximal inhibitory concentration: 22800 nM
Compound 4: the middle estimate sits 1.3-fold (0.11 log units) above what was measured; the range from low to high includes it.
By their numbers in this assay, from the lowest: compounds 4, 2, 3 and 1 (each within the scatter of the next).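

The exchange of 2,6-dimethoxypyrimidin-4-yl for 5,6-dimethoxypyrimidin-4-yl on the sulfonamide nitrogen keeps the same atoms and joins them differently, and in this assay it gives a 1.3-fold lower number from compound 3 to compound 4 (0.11 log units; within the scatter) as its step, so rearranging this substituent stays as silent as exchanging it. The comparisons with the other two substituents read the same way, with a 1.3-fold lower number from compound 2 to compound 4 (0.10 log units; within the scatter) and a 1.4-fold lower number from compound 1 to compound 4 (0.13 log units; within the scatter) both inside the scatter, so hydrogen and all three pyrimidinyl groups now form one unseparated set at this nitrogen, and the series holds no exception to that. No measurement is available that bears on why these numbers stay together.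

Open, from the compounds shown here alone, is whether a substituent of another kind on this nitrogen, such as an acetyl group, a simple alkyl chain or a phenyl ring carrying a carboxylic acid, would produce a step beyond the scatter. Also open is whether this nitrogen matters at all in this assay, since every compound shown keeps the rest of the shared core unchanged and the series offers no active reference point against which to judge it.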